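A 4-ethylphenyl group replaces 4-hydroxy-2-methylphenyl

The source may hold more compounds than are shown below. What is called first, only, known or untested is meant among the compounds shown, and "the series" means these compounds.

In a functional assay on HCT-15 cells (Homo sapiens) for inhibition, read by sulforhodamine B assay, with a stated time of 48 h (on this read-out higher numbers stand for lower toxicity in this test and lower numbers for higher toxicity in this test), compound 1 `Cc1ccc(C2=NN(c3ccc(S(C)(=O)=O)cc3)C(=O)CC2)cc1` gives > 100000 nM as a limit of the assay, not a number. Compound 2 `Cc1cc(O)ccc1C1=NN(c2ccc(S(C)(=O)=O)cc2)C(=O)CC1` also gives > 100000 nM as a limit, so it stands without a number of its own. Together these readings amount to the limit of > 100000 nM in this assay, at which 2 of the 2 values shown sit, and nothing finer. In compound 3 `CCc1ccc(C2=NN(c3ccc(S(C)(=O)=O)cc3)C(=O)CC2)cc1`, 4-ethylphenyl stands in place of 4-hydroxy-2-methylphenyl on a carbon with a double bond to nitrogen (4-ethylphenyl in place of 4-hydroxy-2-methylphenyl on a carbon with a double bond to nitrogen), and the shared core stays as it was. Within the data shown here, the one measured step at this place is a step that the two limits leave unreadable from compound 1 to compound 2 and it offers no size to carry over. With no measured number to work from, no shift can be argued for. In this assay the estimated step is a number no higher from compound 2 to compound 3 (the limit leaves the size open) and no change beyond the scatter is expected. The estimate for compound 3 is 100000 nM with 50000 nM to 200000 nM as its expected range, and another limit is the likeliest report.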

Compound 3, concentration lethal to 50% of the cells: > 100000 nM
Compound 3: no number, only a limit; the forecaster's own chance of this, stated with the estimate: 85%; the middle value lies on the limit itself.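

In this assay, no step can be read among compound 1, compound 2 and compound 3, for each gives a limit of the assay and not a number: the limit of > 100000 nM in this assay, at which 3 of the 3 values shown sit.

The compounds shown leave open whether 4-methylphenyl, 4-hydroxy-2-methylphenyl and 4-ethylphenyl differ at all in this assay.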